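Nitrone series on MDA-MB-231 cells: tert-butyl replaces phenyl

This account rests on a few compounds, and the source may have more. Where it says the series, first, only, none or still open, it means among the compounds named here.

Working notes on a small set of triazolyl nitrones. The read-out is a functional assay on MDA-MB-231 cells (Homo sapiens) for inhibition, read by MTT assay, with a stated time of 24 h; on this read-out lower numbers stand for stronger inhibition and higher numbers for weaker inhibition. Compound 1 `[O-]/[N+](=C\c1cn(-c2ccccc2)nn1)c1ccccc1` carries a phenyl on the triazole nitrogen; in this assay compound 1 gives only a limit, > 100000 nM. Compound 2 `CCCCCCCCCCn1cc(/C=[N+](\[O-])c2ccccc2)nn1` carries a decyl chain there; in this assay compound 2 likewise gives only a limit, > 100000 nM. Compound 3 `[O-]/[N+](=C\c1cn(CCC(F)(F)C(F)(F)C(F)(F)C(F)(F)C(F)(F)C(F)(F)C(F)(F)C(F)(F)F)nn1)c1ccccc1` carries a long fluorinated chain; in this assay compound 3 also gives only a limit, > 100000 nM. Compound 2 thus stands where every value shown stands, at the limit of > 100000 nM in this assay, at which 3 of the 3 values shown sit, and no number separates it from compound 1 or compound 3.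

The next compound, compound 4 `CCCCCCCCCCn1cc(/C=[N+](\[O-])C(C)(C)C)nn1`, differs from compound 2 in one place: tert-butyl in place of phenyl on a double-bonded nitrogen. No measured pair with this change exists here, so the step from compound 2 to compound 4 cannot be anchored to any shown step. Nothing among the shown values points in either direction, and the most likely outcome is expected to be another limit. The step of a number no higher from compound 2 to compound 4 (the limit leaves the size open) is therefore expected to be none beyond the scatter. For compound 4 the estimate is 100000 nM, with a range from 30000 nM to 300000 nM.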

Compound 4, half-maximal inhibitory concentration: 20800 nM
Estimate against measurement, compound 4: 4.8-fold (0.68 log units) above; the measured number lies below the stated range.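

In this assay, going by these compounds alone, the group on the double-bonded nitrogen is the first place where a change moves the read-out: tert-butyl in place of phenyl gives an at least 4.8-fold lower number from compound 2 to compound 4 (0.68 log units; beyond the scatter). From the compounds shown here alone, compound 2 gives only a limit, > 100000 nM, so the full size of this step stays open. Compound 4, at 20800 nM, is the only compound shown with a number rather than a limit, which sets it apart from the rest: the limit of > 100000 nM in this assay, at which 3 of the 4 values shown sit.

The compounds shown leave open whether tert-butyl on this nitrogen gives a similar step with phenyl or the long fluorinated chain on the triazole nitrogen. They also do not separate the loss of the aromatic ring from the presence of tert-butyl itself; cyclohexyl at the same place would bear on that.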